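A few compounds are considered here, and "the series" means these few. Any claim that something is new, unique, unknown or untested is made for them only; others in the source may bear on it.

Three hydrazone compounds sharing one core have been tested so far. Compound 1 `O=C(N/N=C/c1ccccc1Cl)c1cnccn1` gives 69% in an ADME assay on J774 cells (Mus musculus) for cytotoxicity, read by MTT assay, with a stated time of 48 h, tested at 150 ug/mL; on this read-out lower numbers stand for a stronger effect and higher numbers for a weaker effect at the one concentration tested. Compound 3 `O=C(N/N=C/c1ccccc1F)c1cnccn1` differs from compound 1 by fluoro in place of chloro on an aromatic carbon. In this assay compound 3 gives 81%, so the step of a number 12 percentage points higher from compound 1 to compound 3 (beyond the scatter) points toward a weaker effect. Compound 2 `O=C(N/N=C/c1cccc(Cl)c1)c1cnccn1` is built from the same atoms as compound 1 joined differently; the difference between the two cores is not broken down here. Compound 2 gives 100% in this assay, the highest of the three numbers and beyond the scatter from both others.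

Compound 4 `O=C(N/N=C/c1cccc(F)c1)c1cnccn1` has not yet been measured. It differs from compound 2 by fluoro in place of chloro on an aromatic carbon. This is the same kind of change as from compound 1 to compound 3, though the place differs: there the fluoro sits ortho to a large group, here meta to a large group. Beside the measured step of a number 12 percentage points higher from compound 1 to compound 3 (beyond the scatter), the expected step is a number 1 percentage points lower from compound 2 to compound 4 (within the scatter), because compound 2 already gives 100% and little room remains. Compound 4 is therefore estimated at 99%, between 88% and 106%.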

Compound 4, a percentage reported as activity, at one concentration (the size of the read-out at that concentration, not a potency): 40%
Compound 4: middle estimate off by 59 percentage points, on the high side; the measured number lies below the stated range.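

In this assay the swap of chloro for fluoro gives a number 60 percentage points lower from compound 2 to compound 4 (beyond the scatter), and this lower number points toward a stronger effect. Set beside the earlier step, the same swap does not carry over from one core to the other, and its direction even reverses: the same change on two cores in this assay, a number 12 percentage points higher (beyond the scatter) from compound 1 to compound 3 and a number 60 percentage points lower (beyond the scatter) from compound 2 to compound 4, 72 percentage points apart, beyond the scatter of two such steps

This shows that a result for this swap on the core of compound 1 gives no safe forecast for the core of compound 2. Among the compounds shown here, it does not show whether the place of the halogen on the ring or something else accounts for the difference, and with only one pair on each core it sets no rule for the series.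

The compounds shown carry only chloro or fluoro on the ring, and how a methoxy group, a nitrile or an amine would behave in those places remains open. Also open, from the compounds shown here alone, is which way the swap of chloro for fluoro would go on any further core.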